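Alkoxycarbonyl chain extension across two cores

The compounds below may be only part of what the source reports. "The series", "measured", "known", "first", "only" and "open" are said of these compounds alone.

Compound 1 `COC(=O)c1cc(N2C(=O)C3=C(CCCC3)C2=O)c(F)cc1Cl` carries a methoxycarbonyl group on the shared core; in a functional assay on the whole organism for inhibition, with Scenedesmus acutus as the target (on this read-out higher numbers stand for weaker inhibition and lower numbers for stronger inhibition), compound 1 gives 67.6 nM. Compound 2 `CCCCOC(=O)c1cc(N2C(=O)C3=C(CCCC3)C2=O)c(F)cc1Cl` differs from compound 1 by propyl in place of hydrogen on a saturated chain carbon bound to an oxygen next to a carbonyl group, and in this assay compound 2 gives 126 nM. The step of a 1.9-fold higher number from compound 1 to compound 2 (0.27 log units; within the scatter) is therefore small. Compound 3 `CCCCCOC(=O)c1cc(N2C(=O)C3=C(CCCC3)C2=O)ccc1Cl` sits on a second core; the difference between the two cores is not broken down here. In this assay compound 3 gives 4470 nM, the highest of the three numbers, and its gap to compound 2 and to compound 1 lies beyond the scatter in both cases.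

Compound 4 `CCCCCCCCOC(=O)c1cc(N2C(=O)C3=C(CCCC3)C2=O)ccc1Cl` has not been measured. It differs from compound 3 by propyl in place of hydrogen on a saturated chain carbon, five bonds along the chain from an oxygen next to a carbonyl group. This is the same kind of change as from compound 1 to compound 2, but not the same: in the earlier pair the propyl enters on a saturated chain carbon bound to an oxygen next to a carbonyl group, whereas here it enters on a saturated chain carbon five bonds along the chain from an oxygen next to a carbonyl group. Among the measured compounds shown here, the only measured example of this kind of change, a 1.9-fold higher number from compound 1 to compound 2 (0.27 log units; within the scatter), stayed within the scatter, and that is the main support for the expectation. For the measured compounds named here, compound 3 already gives the weakest inhibition of the three, and the second core has only one measured member, so the range is kept wide. The estimated step is a 1.8-fold higher number from compound 3 to compound 4 (0.25 log units; within the scatter). For compound 4 the expected value in this assay is 8000 nM, with a range from 3000 nM to 25000 nM.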

Compound 4, half-maximal inhibitory concentration: > 100000 nM
Compound 4: no number, only a limit; the forecaster's own chance of this, stated with the estimate: 15%; middle value at least 12-fold (1.09 log units) from the limit.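

In this assay compound 4 gives > 100000 nM, which is a limit of the assay and not a number: the limit of > 100000 nM in this assay, at which 1 of the 4 values shown sits. The change of propyl in place of hydrogen does not carry over at a constant size from the core of compound 1 to the core of compound 3, with an at least 22-fold higher number from compound 3 to compound 4 (1.34 log units; beyond the scatter) set against a 1.9-fold higher number from compound 1 to compound 2 (0.27 log units; within the scatter): the same change on two cores in this assay, a 1.9-fold higher number (0.27 log units; within the scatter) from compound 1 to compound 2 and an at least 22-fold higher number (1.34 log units; beyond the scatter) from compound 3 to compound 4, at least 12-fold (1.07 log units) apart, beyond the scatter of two such steps. This does not separate the core from the place of the change, since the propyl enters on a saturated chain carbon bound to an oxygen next to a carbonyl group in the first pair and on a saturated chain carbon, five bonds along the chain from an oxygen next to a carbonyl group, in the second; with one pair on each core, no rule for the series follows.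

The compounds shown leave open how the core of compound 1 responds to a longer chain, such as the one in compound 4, and how the core of compound 3 responds to a shorter one, such as a butyl ester. From the compounds shown here alone, a carboxylic acid in place of the ester on either core also remains open, as does the true size of the step behind the limit of compound 4.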